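The source may hold more compounds than are shown below. What is called first, only, known or untested is meant among the compounds shown, and "the series" means these compounds.

Working notes on the series, with values from an in vitro ADME assay on microsomes from liver (Mus musculus) for metabolic stability; a higher number here means faster removal of the compound, a lower number slower removal:

- Compound 1 `Cc1cc(Nc2ccc(S(F)(F)(F)(F)F)cc2)n2nc(C(F)(F)F)nc2n1` gives < 6 mL.min-1.g-1 (a limit)
- Compound 2 `Cc1cc(Nc2cccc(Cl)c2)n2nc(C(C)(F)F)nc2n1` gives 72.2 mL.min-1.g-1
- Compound 3 `CCc1nc2nc(C)cc(Nc3ccc(Cl)cc3)n2n1` gives 63.1 mL.min-1.g-1
- Compound 4 `CSc1nc2nc(C)cc(Nc3ccc(S(F)(F)(F)(F)F)cc3)n2n1` is not yet measured

Compound 1 has only a limit in this assay, < 6 mL.min-1.g-1 and no number. Compound 2 at 72.2 mL.min-1.g-1 and compound 3 at 63.1 mL.min-1.g-1 do not differ beyond the scatter. Going by the values given here, no two measured compounds differ in only one place, so no measured step bears directly on the change ahead.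

Compound 4 keeps the rest of compound 1 and carries methylsulfanyl in place of trifluoromethyl on an aromatic carbon. The exchange sits on a five-membered aromatic ring with 3 nitrogen, between two ring nitrogen atoms.

Among the compounds with values here, with no measured step to lean on, the expectation is a moderate rise in this assay beyond the scatter, and the uncertainty is wide. The expected size is an at least 2.5-fold higher number from compound 1 to compound 4 (0.39 log units; beyond the scatter) and is an estimate only. Compound 4 is estimated at 15 mL.min-1.g-1 in this assay, with an expected range of 7 mL.min-1.g-1 to 40 mL.min-1.g-1 as the measurement stands open.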

Compound 4, intrinsic clearance in microsomes: 108 mL.min-1.g-1
Compound 4: middle estimate off by 7.2-fold (0.86 log units), on the low side, and the stated range ends below it.
By their numbers in this assay, from the lowest: compounds 3, 2 and 4 (each within the scatter of the next). At a limit, below all of these: compound 1.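

In this assay, methylsulfanyl in place of trifluoromethyl on an aromatic carbon, between two ring nitrogen atoms, gives an at least 18-fold higher number from compound 1 to compound 4 (1.25 log units; beyond the scatter). Going by these compounds alone, this is the first step between compounds that differ in one place, and it shows that this one position, with the rest of compound 1 unchanged, can move the read-out by a large margin. Compound 1 stands at a limit and not at a number, so the true size of the step stays unknown and the printed size is only its lower bound: the limit of < 6 mL.min-1.g-1 in this assay, at which 1 of the 4 values shown sits.

The compounds shown cannot separate what comes from losing trifluoromethyl from what comes from gaining methylsulfanyl, and they give no cause for the step. Also open, as far as these compounds go, is where a methoxy group or an amine at this position would fall relative to compound 1 and compound 4, and whether the step keeps its size when the group on the aniline nitrogen is a chlorophenyl ring, as in the other compounds.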